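Three Hydrazones Beyond the Toxicity Limit, One Analogue Pending

The compounds below may be only part of what the source reports. "The series", "measured", "known", "first", "only" and "open" are said of these compounds alone.

Compound 1 `COc1cc(/C=N/NC(=O)C(C)Oc2ccc([N+](=O)[O-])cc2)ccc1OC(=O)c1sc2ccccc2c1Cl`, compound 2 `COc1cc(/C=N/NC(=O)COc2ccc([N+](=O)[O-])cc2)ccc1OC(=O)c1sc2ccccc2c1Cl` and compound 3 `O=C(COc1ccc([N+](=O)[O-])cc1)N/N=C/c1ccccc1OC(=O)c1sc2ccccc2c1Cl` were examined in an ADME assay on Huh-7 cells (Homo sapiens) for cytotoxicity, read by a luciferase reporter and MTT assay, with a stated time of 72 h; on this read-out higher numbers stand for lower toxicity in this test and lower numbers for higher toxicity in this test. Compound 1 reaches only the limit of > 125000 nM. Compound 2 likewise gives only the limit of > 125000 nM. Compound 3 also stops at the limit of > 125000 nM. All three stand at the limit of > 125000 nM in this assay, at which 3 of the 3 values shown sit, so none of them is read as a number in this assay. The change from compound 2 to compound 1 is methyl in place of hydrogen on a saturated chain carbon bound to a carbonyl carbon and an oxygen on an aromatic ring, and its step in this assay is a step that the two limits leave unreadable from compound 2 to compound 1. Compound 4 `CC(Oc1ccc([N+](=O)[O-])cc1)C(=O)N/N=C/c1ccccc1OC(=O)c1sc2ccccc2c1Cl` has not yet been measured in this assay. It carries the same change relative to compound 3: methyl in place of hydrogen on a saturated chain carbon bound to a carbonyl carbon and an oxygen on an aromatic ring. The difference between the core of compound 3 and that of compound 2 is not broken down here. The expected step is a step that the limit leaves unreadable from compound 3 to compound 4. That expectation rests on compound 3 sitting at the limit of > 125000 nM in this assay, at which 3 of the 3 values shown sit, and on the earlier step that the two limits leave unreadable from compound 2 to compound 1. Compound 4 is therefore estimated at 150000 nM, between 90000 nM and 300000 nM, most likely reported again as a limit rather than a number.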

Compound 4, half-maximal cytotoxic concentration: > 125000 nM
Compound 4 gave a limit, no number; the forecaster's own chance of this, stated with the estimate: 85%; the middle value is on the limit's open side.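

Among these compounds, compound 4 reaches only a limit in this assay, so like compound 3 it gives no number, and no step between compound 3 and compound 4 can be read: the limit of > 125000 nM in this assay, at which 4 of the 4 values shown sit. The compounds shown leave open at what concentration any of them would become cytotoxic in this assay, and whether methyl in place of hydrogen alters that concentration at all.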